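Trifluoromethyl in place of fluoro in compound 1

A few compounds are considered here, and "the series" means these few. Any claim that something is new, unique, unknown or untested is made for them only; others in the source may bear on it.

Within the data shown here, in a functional assay on HepG2 cells (Homo sapiens) for cytotoxicity, read by MTT assay, with a stated time of 24 h (on this read-out lower numbers stand for stronger inhibition and higher numbers for weaker inhibition), compound 1 (`O=C1/C(=C/c2cccnc2)CN(S(=O)(=O)c2ccc(C(F)(F)F)cc2)C/C1=C\c1ccccc1F`) gives 2400 nM, at the low end of the three numbers known so far. Compound 3 (`O=C1/C(=C/c2ccncc2)CN(S(=O)(=O)c2ccc(C(F)(F)F)cc2)C/C1=C\c1ccccc1F`) gives 4030 nM, and compound 2 (`O=C1/C(=C/c2cccnc2)CN(S(=O)(=O)c2ccc(Cl)cc2)C/C1=C\c1ccccc1F`) gives 12400 nM. The unmeasured compound 4 (`O=C1/C(=C/c2cccnc2)CN(S(=O)(=O)c2ccc(C(F)(F)F)cc2)C/C1=C\c1ccccc1C(F)(F)F`) differs from compound 1 by trifluoromethyl in place of fluoro on an aromatic carbon, ortho to a large group, turning 2-fluorophenyl into 2-(trifluoromethyl)phenyl.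

Neither measured step touches this place. Swapping pyridin-3-yl for pyridin-4-yl gives a 1.7-fold higher number from compound 1 to compound 3 (0.23 log units; within the scatter). Among the measured compounds shown here, putting chloro in place of trifluoromethyl gives a 5.2-fold higher number from compound 1 to compound 2 (0.71 log units; beyond the scatter), the only step that involves trifluoromethyl, but on a different aromatic group, so compound 2 offers only weak guidance here. No clear direction follows from these two steps, and a large move is not expected. The estimated change is a 1.3-fold higher number from compound 1 to compound 4 (0.10 log units; within the scatter), which is expected to stay within the scatter. For compound 4 the expected value is 3000 nM, with an estimated range of 1000 nM to 9000 nM.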

Compound 4, half-maximal inhibitory concentration: 1710 nM
The estimate for compound 4 lay 1.8-fold (0.24 log units) above the measured number; measured number inside the range.
By their numbers in this assay, from the lowest: compounds 4, 1 and 3 (each within the scatter of the next, the first and the last beyond it); then compound 2.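

In this assay, replacing fluoro with trifluoromethyl on the aromatic carbon, which turns 2-fluorophenyl into 2-(trifluoromethyl)phenyl, gives a 1.4-fold lower number from compound 1 to compound 4 (0.15 log units; within the scatter) and so leaves compound 4 and compound 1 indistinguishable on this read-out. Among these compounds, this place therefore accepts the group with more heavy atoms without a change beyond the scatter, whereas the one step that swaps trifluoromethyl on the other aromatic group, a 5.2-fold higher number from compound 1 to compound 2 (0.71 log units; beyond the scatter), lies beyond it. No measurement given here bears on why this exchange reads as it does.

The compounds shown leave open how an amine, a methoxy group or a carboxylic acid would read at this place. They also leave open whether the same exchange would read alike with pyridin-4-yl as in compound 3, or with chloro as in compound 2.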